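The source may hold more compounds than are shown below. What is called first, only, known or untested is meant among the compounds shown, and "the series" means these compounds.

Three related compounds have been tested in a functional assay on K562 cells (Homo sapiens) for inhibition, read by trypan blue exclusion, with a stated time of 72 h; a lower number here means a stronger inhibitor, a higher number a weaker inhibitor. Compound 1 `Cn1c(=O)c(S(=O)(=O)c2ccc(F)cc2F)cc2cnc(Nc3ccc4[nH]c(C(=O)O)cc4c3)nc21` gives 10000 nM in this assay. Compound 2 `Cc1ccc(S(=O)(=O)c2cc3cnc(Nc4cccc5cccnc45)nc3n(C)c2=O)cc1` gives 10000 nM, a number level with that of compound 1 and within the scatter. Compound 3 `COc1ccc(Nc2ncc3cc(S(=O)(=O)c4ccc(Cl)cc4)c(=O)n(C)c3n2)cc1` gives 15000 nM, a number that also lies within the scatter of compound 1. All three compounds are weak inhibitors and stand close together. Compound 4 `Cn1c(=O)c(S(=O)(=O)c2ccc(F)cc2F)cc2cnc(Nc3ccncn3)nc21` has not yet been measured. It differs from compound 1 in one place: pyrimidin-4-yl in place of 2-carboxy-1H-indol-5-yl on a nitrogen on an aromatic ring. Within the data shown here, no measured pair shows a comparable change, so nothing sets the size of the step. Compound 4 is expected to give 10000 nM, with a range from 3000 nM to 30000 nM. The expected step is no change at the digits printed from compound 1 to compound 4 (within the scatter), no larger than the scatter.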

Compound 4, half-maximal inhibitory concentration: 30000 nM
For compound 4 the middle estimate is 3.0-fold (0.48 log units) below the measured one; low and high end bracket the measured number.
By their numbers in this assay, from the lowest: compounds 1, 2, 3 and 4 (each within the scatter of the next, the first and the last beyond it).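

Among these compounds, putting pyrimidin-4-yl in place of 2-carboxy-1H-indol-5-yl on this nitrogen gives, in this assay, a 3.0-fold higher number from compound 1 to compound 4 (0.48 log units; beyond the scatter) as the first readable step at this position. It shows that the group here can move the number beyond the scatter, even among weak inhibitors. No available evidence explains this step.

The change swaps a two-ring group carrying a carboxylic acid for a one-ring group, so these compounds cannot separate the loss of the acid from the loss of the second ring. A plain 1H-indol-5-yl group would separate the two.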